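A few compounds are considered here, and "the series" means these few. Any claim that something is new, unique, unknown or untested is made for them only; others in the source may bear on it.

Working notes on the series. In an ADME assay on liver for metabolic stability, with Liver microsome (Homo sapiens) as the target, read by LC-MS, using microsomes (on this read-out higher numbers stand for fast clearance and lower numbers for slow clearance), compound 1 `O=C(NCc1cc(Cl)ccc1-n1cnnn1)[C@@H]1CC=NN1C(=O)[C@H](O)c1ccccc1` gives < 12 mL.min-1.g-1, which is a limit of the assay and not a number. Compound 2 `O=C(NCc1cc(Cl)ccc1-n1cnnn1)[C@@H]1C[C@@H]2C[C@@H]2N1C(=O)[C@H](O)C1CCCCC1` gives 150 mL.min-1.g-1 and compound 3 `O=C(NCc1cc(Cl)ccc1-n1cnnn1)[C@@H]1C[C@H]2C[C@H]2N1C(=O)[C@H](O)CC1CC1` gives 25 mL.min-1.g-1. Neither carries the phenyl, but both also differ from compound 1 in the core, so they offer only loose guidance. Compound 4 `CC(C)CC[C@@H](O)C(=O)N1N=CC[C@H]1C(=O)NCc1cc(Cl)ccc1-n1cnnn1` has isopentyl in place of phenyl on a saturated chain carbon bound to a carbonyl carbon and an oxygen on a saturated carbon. A rise in this assay is expected, with compound 3 at 25 mL.min-1.g-1 as the guide. The expected change is an at least 2.0-fold higher number from compound 1 to compound 4 (0.31 log units; beyond the scatter). For compound 4 the estimated value is 25 mL.min-1.g-1, with an expected range of 12 mL.min-1.g-1 to 60 mL.min-1.g-1.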

Compound 4, intrinsic clearance in microsomes: 47 mL.min-1.g-1
Compound 4: middle estimate off by 1.9-fold (0.27 log units), on the low side; the range from low to high includes it.
By their numbers in this assay, from the lowest: compounds 3 and 4 (each within the scatter of the next); then compound 2. At a limit, below all of these: compound 1.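

Compounds 2 and 3 differ from compound 1 in the core as well, so this is the first change shown at this position alone: in this assay, isopentyl in place of phenyl gives an at least 3.9-fold higher number from compound 1 to compound 4 (0.59 log units; beyond the scatter). On the shared core, the read-out therefore responds to the group at this position. Compound 1 stands at a limit and not a number, so the size of the step remains a lower bound: the limit of < 12 mL.min-1.g-1 in this assay, at which 1 of the 4 values shown sits.

As far as these compounds go, whether the aromatic ring or the isopentyl chain drives the step stays open. From the compounds shown here alone, how a pyridine ring or an ethyl chain would read here on the core of compound 1 also stays open.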